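A Phenylsulfanyl Group Replaces the Chlorothiophene

A few compounds are considered here, and "the series" means these few. Any claim that something is new, unique, unknown or untested is made for them only; others in the source may bear on it.

Of the compounds shown here, three sharing one core have been measured in a functional assay on Jurkat cells for inhibition of nuclear factor NF-kappa-B complex (Homo sapiens); a higher number here means a weaker inhibitor, a lower number a stronger inhibitor. Compound 1 `CCOC(=O)c1cnc(CC)nc1NN1C(=O)C=C(C)C1=O` gives 10000 nM, compound 2 `CCOC(=O)c1cnc(-c2ccsc2)nc1NN1C(=O)C=C(C)C1=O` gives 100 nM, and compound 3 `CCOC(=O)c1cnc(-c2ccc(Cl)s2)nc1NN1C(=O)C=C(C)C1=O` gives 300 nM. Compound 3 therefore stands second highest of the three numbers, closest to compound 2 and far from compound 1. The steps show a 100-fold lower number from compound 1 to compound 2 (2.00 log units; beyond the scatter) and a 33-fold lower number from compound 1 to compound 3 (1.52 log units; beyond the scatter), while a 3.0-fold higher number from compound 2 to compound 3 (0.48 log units; beyond the scatter).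

Compound 4 `CCOC(=O)c1cnc(Sc2ccccc2)nc1NN1C(=O)C=C(C)C1=O` is not yet measured. It differs from compound 3 in one place: phenylsulfanyl in place of 5-chlorothiophen-2-yl on an aromatic carbon. Within the data shown here, the steps that bear on this change are the two from compound 1, which show that each ring group on this carbon brought a large drop in this assay, and the step from compound 2 to compound 3, which shows that exchanging one ring group for another shifts the number only modestly. As compound 4 keeps a ring group at the same place, the step of a 1.7-fold higher number from compound 3 to compound 4 (0.22 log units; within the scatter) is expected to be modest, at most a small rise. Compound 4 is therefore estimated at 500 nM in this assay, with a range from 100 nM to 3000 nM.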

Compound 4, half-maximal inhibitory concentration: 1000 nM
Beside the measured number, compound 4's estimate is 2.0-fold (0.30 log units) below it; low and high end bracket the measured number.
By their numbers in this assay, from the lowest: compound 2; then compound 3; then compound 4; then compound 1.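

In this assay, among these compounds, compound 4 is the first case where the ring group at this carbon is held through sulfur, and it keeps only part of the gain over ethyl (a 10-fold lower number from compound 1 to compound 4 (1.00 log units; beyond the scatter)). Against the two directly attached thiophene groups it gives ground (a 3.3-fold higher number from compound 3 to compound 4 (0.52 log units; beyond the scatter); a 10-fold higher number from compound 2 to compound 4 (1.00 log units; beyond the scatter)), so the choice of ring group here spans a wider range than the earlier step (a 3.0-fold higher number from compound 2 to compound 3 (0.48 log units; beyond the scatter)) had indicated. No supporting data are available to explain this difference.

The compounds shown leave open whether the sulfur link or the replacement of the thiophene by a benzene ring accounts for the higher number. They also leave open how a directly attached phenyl group, a phenylamino group or a morpholine ring would read at this carbon.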